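The source may report more compounds than this note shows. Statements on the series, on what has been measured and on what is new or still open speak of the compounds shown alone.

Compound 2 `COc1cc2c(Oc3ccc(NC(=O)N/N=C/c4ccncc4)cc3F)ccnc2cc1OCCCN1CCCCC1` and compound 1 `COc1cc2c(Oc3ccc(NC(=O)N/N=C/c4ccc(O)cc4)cc3F)ccnc2cc1OCCCN1CCCCC1` share one core and differ only in the ring that sits on a carbon with a double bond to nitrogen. In a functional assay on MDA-MB-231 cells (Homo sapiens) for cytotoxicity, read by MTT assay, with a stated time of 72 h (on this read-out higher numbers stand for weaker inhibition and lower numbers for stronger inhibition), compound 2 gives 1400 nM and compound 1 gives 790 nM, so the step of a 1.8-fold higher number from compound 1 to compound 2 (0.25 log units; within the scatter) stays within the scatter. Compound 3 `COc1cc2c(Oc3ccc(NC(=O)N/N=C/c4cccs4)cc3F)ccnc2cc1OCCCN1CCCCC1` differs from compound 2 by thiophen-2-yl in place of pyridin-4-yl on a carbon with a double bond to nitrogen. Going by the values given here, the only step that bears on such a ring swap at this position was small, so in this assay no change beyond the scatter is expected, in either direction. Compound 3 is therefore estimated at 1100 nM, between 450 nM and 2800 nM, with an expected step of a 1.3-fold lower number from compound 2 to compound 3 (0.10 log units; within the scatter).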

Compound 3, half-maximal inhibitory concentration: 1260 nM
Beside the measured number, compound 3's estimate is 1.1-fold (0.06 log units) below it; measured number inside the range.
By their numbers in this assay, from the lowest: compounds 1, 3 and 2 (each within the scatter of the next).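

Putting thiophen-2-yl on this carbon gives a 1.1-fold lower number from compound 2 to compound 3 (0.05 log units; within the scatter) in this assay, and replacing 4-hydroxyphenyl with it gives a 1.6-fold higher number from compound 1 to compound 3 (0.20 log units; within the scatter) as the second step. A five-membered aromatic ring with sulfur therefore joins two six-membered aromatic rings here, and no step among these three compounds rises above the scatter. Nothing measured here accounts for this.

On these data alone, whether an aliphatic amine or a carboxylic acid on the ring would move the number beyond the scatter remains open. So does the effect of an open alkyl chain in place of the ring.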